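Moving the carboxyl and swapping chloro for methyl

The source may report more compounds than this note shows. Statements on the series, on what has been measured and on what is new or still open speak of the compounds shown alone.

Measured compounds:
Compound 1, `Cc1c(OCCCCOc2ccc(C(=O)O)cc2)ccc(C(=O)CC2CCCC2)c1O`: in an assay on HEK293 cells for positive allosteric modulation of metabotropic glutamate receptor 3 (Rattus norvegicus), read by thallium flux, with a stated time of 2.5 min (a higher number here means that more compound is needed for the effect, a lower number that less compound is needed), compound 1 gives > 10000 nM, a limit of the assay.
Compound 2, `Cc1c(OCCCCOc2ccc(C(=O)O)cc2Cl)ccc(C(=O)CC2CCCC2)c1O`: in this assay compound 2 gives > 10000 nM, also a limit of the assay.

Within the data shown here, compound 2 therefore has no number of its own in this assay, only a limit, and the one other value shown is a limit as well. Among the measured compounds shown here, the step that the two limits leave unreadable from compound 1 to compound 2 is the only measured step, and it cannot be read because of the limit of > 10000 nM in this assay, at which 2 of the 2 values shown sit.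

Compound 3, `Cc1ccc(C(=O)O)cc1OCCCCOc1ccc(C(=O)CC2CCCC2)c(O)c1C`, differs from compound 2 by 5-carboxy-2-methylphenyl in place of 4-carboxy-2-chlorophenyl on an oxygen on a saturated carbon. For the measured compounds named here, no measured step bears on this change, so the expectation rests on the fact that both measured compounds sit at the limit; compound 3 most likely stays there too, and the step of a number no higher from compound 2 to compound 3 (the limit leaves the size open) is expected to lie within the scatter. Compound 3 is expected at 10000 nM, in a range from 3000 nM to 30000 nM.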

Compound 3, half-maximal effective concentration: > 10000 nM
Compound 3 ended at the assay's limit; the forecaster's own chance of this, stated with the estimate: 80%; the middle value sits exactly at the limit.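

Neither step from compound 1 to compound 3 nor from compound 2 to compound 3 can be read in this assay, because all three compounds share one limit: the limit of > 10000 nM in this assay, at which 3 of the 3 values shown sit. The compounds shown leave open how far each lies from that limit, and whether 5-carboxy-2-methylphenyl and 4-carboxy-2-chlorophenyl differ at all.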